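Swapping the aryl group: expected toxicity of compound 4

A few compounds are considered here, and "the series" means these few. Any claim that something is new, unique, unknown or untested is made for them only; others in the source may bear on it.

In an ADME assay on Huh7.5.1 cells (Homo sapiens) for cytotoxicity, read by ATP content, with a stated time of 48 h (on this read-out lower numbers stand for higher toxicity in this test and higher numbers for lower toxicity in this test), three compounds have been measured so far:
Compound 1 `Cc1ccccc1-c1nc(CN2CCC(C(=O)NCCCN3CC(C)(C)CC(C)(C)C3)CC2)c(C)o1` gives 4380 nM.
Compound 2 `Cc1oc(-c2ccccc2Cl)nc1CN1CCC(C(=O)NCCCN2C[C@H](C)C[C@H](C)C2)CC1` gives 16500 nM.
Compound 3 `Cc1ccccc1-c1nc(CN2CCC(C(=O)NCCCN3CC4CCCC(C4)C3)CC2)c(C)o1` gives 10900 nM.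

Compound 2 has the highest number of the three; its gap to compound 3 lies within the scatter, while its gap to compound 1 lies beyond it. Compound 4 `Cc1ccc(-c2nc(CN3CCC(C(=O)NCCCN4C[C@H](C)C[C@H](C)C4)CC3)c(C)o2)cc1` differs from compound 2 in one place: 4-methylphenyl in place of 2-chlorophenyl on an aromatic carbon. Among the compounds with values here, the only measured step between two compounds, a 2.5-fold higher number from compound 1 to compound 3 (0.40 log units; beyond the scatter), concerns a group on a saturated chain carbon and not the aromatic ring altered here, so it offers no guide to this change. Lacking any direct precedent, no step beyond the scatter is expected in this assay. Compound 4 is therefore estimated at 12000 nM, within 4000 nM to 35000 nM, which means an expected 1.4-fold lower number from compound 2 to compound 4 (0.14 log units; within the scatter).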

Compound 4, half-maximal cytotoxic concentration: 4330 nM
Estimate against measurement, compound 4: 2.8-fold (0.44 log units) above, and the stated range covers the measured number.
By their numbers in this assay, from the lowest: compounds 4 and 1 (each within the scatter of the next); then compounds 3 and 2 (each within the scatter of the next).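

In this assay, replacing 2-chlorophenyl with 4-methylphenyl gives a 3.8-fold lower number from compound 2 to compound 4 (0.58 log units; beyond the scatter) while the rest of the molecule stays the same. This is the first step shown for this aromatic carbon, and it shows that the aryl group there can move the number beyond the scatter, towards higher toxicity in this test. Nothing measured here accounts for the shift. The swap changes both the substituent and where it sits on the phenyl ring, and these two changes cannot be separated. On these data alone, whether 4-chlorophenyl or plain phenyl would fall nearer compound 2 or compound 4 remains open.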